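Amide nitrogen swap from aryl to benzyl in this series

This account rests on a few compounds, and the source may have more. Where it says the series, first, only, none or still open, it means among the compounds named here.

Compound 1 `O=C(/C=C/c1coc2cc(O)ccc2c1=O)NCc1ccc(F)cc1` in a functional assay on A549 cells (Homo sapiens) for inhibition, read by MTT assay, with a stated time of 48 h (on this read-out higher numbers stand for weaker inhibition and lower numbers for stronger inhibition), gives > 100000 nM, a limit of the assay and not a number.
Compound 2 `CCOc1ccc(NC(=O)/C=C/c2coc3cc(OC)ccc3c2=O)cc1` in this assay likewise gives only a limit, > 100000 nM.
Compound 3 `O=C(/C=C/c1coc2cc(O)ccc2c1=O)Nc1ccccc1` in this assay gives 24400 nM.

Two of the three values sit at the limit (the limit of > 100000 nM in this assay, at which 2 of the 3 values shown sit), and compound 2 is one of them; nothing beyond that limit is known of it. Among the measured compounds shown here, the single measured step, an at least 4.0-fold lower number from compound 1 to compound 3 (0.61 log units; beyond the scatter), puts phenyl in place of 4-fluorobenzyl on an amide-type nitrogen and carries the number from the limit down to a read value. Compound 4 `COc1ccc2c(=O)c(/C=C/C(=O)NCc3ccc(F)cc3F)coc2c1` differs from compound 2 by 2,4-difluorobenzyl in place of 4-ethoxyphenyl on an amide-type nitrogen. This change runs in the opposite sense to the measured step, from an aryl to a benzyl group on the amide-type nitrogen, and compound 1, the benzyl case among the measured compounds, stands at the limit. The step from compound 1 to compound 3 therefore bears on it directly and suggests no move toward a lower number. With compound 2 already at the limit, the expected step is a step that the limit leaves unreadable from compound 2 to compound 4, in the direction of weaker inhibition or no change resolvable within the scatter. Compound 4 is estimated at 150000 nM, within 60000 nM to 400000 nM, and is most likely to be reported as a limit in this assay.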

Compound 4, half-maximal inhibitory concentration: 13300 nM
The estimate for compound 4 lay 11-fold (1.05 log units) above the measured number; measured number below the stated range.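

In this assay, a benzyl group on the amide-type nitrogen is not tied to the limit: 2,4-difluorobenzyl in place of 4-ethoxyphenyl gives an at least 7.5-fold lower number from compound 2 to compound 4 (0.87 log units; beyond the scatter), ending on a read value. This runs in the opposite sense to an at least 4.0-fold lower number from compound 1 to compound 3 (0.61 log units; beyond the scatter), where the aryl group carries the lower number, so no single order of aryl and benzyl holds on this nitrogen across the two pairs, which stand on different cores. The size of the new step remains a bound, with its starting end at a limit: the limit of > 100000 nM in this assay, at which 2 of the 4 values shown sit.

Open, on these data alone, is how much of the step belongs to the two fluorines and how much to the benzyl link itself. Also open, as far as these compounds go, is how the number responds to a longer chain ending in a morpholine on the amide-type nitrogen.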